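The source may hold more compounds than are shown below. What is called first, only, known or untested is meant among the compounds shown, and "the series" means these compounds.

Measured in an ADME assay on HEK293 cells (Homo sapiens) for cytotoxicity, read by MTT assay, with a stated time of 48 h; on this read-out lower numbers stand for stronger inhibition and higher numbers for weaker inhibition:
- compound 1 `COc1cc(NC(=O)c2ccc(Cl)c([N+](=O)[O-])c2)ccc1NS(C)(=O)=O`: 164000 nM
- compound 2 `CCS(=O)(=O)Nc1ccc(NC(=O)c2ccc(Cl)c([N+](=O)[O-])c2)cc1OC`: 63700 nM
- compound 3 `COc1cc(NC(=O)c2ccc(Cl)c([N+](=O)[O-])c2)ccc1NS(=O)(=O)C(F)(F)F`: a limit of the assay rather than a number, > 250000 nM

Compound 1 carries the highest of the two numbers in this assay; its nearest neighbour is compound 2, reached by a 2.6-fold lower number from compound 1 to compound 2 (0.41 log units; beyond the scatter), and compound 3 sits at the limit of > 250000 nM in this assay, at which 1 of the 3 values shown sits. The next compound is compound 4 `CS(=O)(=O)Nc1ccc(NC(=O)c2ccc(Cl)c([N+](=O)[O-])c2)cc1F`, and the change from compound 1 is fluoro in place of methoxy on an aromatic carbon.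

Within the data shown here, no measured step touches that position. The steps shown, a 2.6-fold lower number from compound 1 to compound 2 (0.41 log units; beyond the scatter), an at least 1.5-fold higher number from compound 1 to compound 3 (0.18 log units; that floor lies within the scatter) and an at least 3.9-fold higher number from compound 2 to compound 3 (0.59 log units; beyond the scatter), all exchange the substituent on the sulfonyl sulfur while the methoxy stays fixed, so they give no direct guide to a methoxy-for-fluoro swap on the ring. What they do show is that the whole set moves within a narrow band of weak cytotoxicity, with compound 3 reaching the assay ceiling.

Among the measured compounds shown here, with no bearing step available, the expectation for compound 4 in this assay is no step beyond the scatter, a 1.0-fold lower number from compound 1 to compound 4 (0.01 log units; within the scatter). Compound 4 is therefore estimated at 160000 nM, within 70000 nM to 250000 nM. Because compound 3 already sits at the limit of > 250000 nM in this assay, at which 1 of the 3 values shown sits, a limit rather than a number is a real possibility for compound 4 as well.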

Compound 4, half-maximal inhibitory concentration: 23100 nM
Beside the measured number, compound 4's estimate is 6.9-fold (0.84 log units) above it; the whole stated range lies above it.
By their numbers in this assay, from the lowest: compound 4; then compound 2; then compound 1. At a limit, above all of these: compound 3.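

In this assay, the aromatic carbon ortho to a methanesulfonamido group proves to be a position that responds to change, which the sulfonyl-side steps could not show: fluoro in place of methoxy gives a 7.1-fold lower number from compound 1 to compound 4 (0.85 log units; beyond the scatter). Among these compounds, every earlier step altered only the substituent on the sulfonyl sulfur with the methoxy held fixed, and the one earlier step down from compound 1, a 2.6-fold lower number from compound 1 to compound 2 (0.41 log units; beyond the scatter), is the smaller of the two in size, so the series is no longer confined to sulfonyl-side changes as a source of movement in this read-out. Nothing measured here accounts for the size of the step, and the pair alone gives no cause for it.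

With only fluoro set against methoxy at this position, the loss of methoxy and the arrival of fluoro cannot be told apart, and a plain hydrogen, a chloro, a methyl or an amine on the same carbon would be needed to separate them. As far as these compounds go, it also stays open whether the ethyl on the sulfonyl sulfur, as in compound 2, would add to the fluoro change in a single compound or fail to do so.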